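Trading Chlorines for Methoxy Groups on a Chalcone Pyrazole

The source may hold more compounds than are shown below. What is called first, only, known or untested is meant among the compounds shown, and "the series" means these compounds.

Of the compounds shown here, two sharing a pyrazole-linked chalcone core have been tested in a functional assay on MDA-MB-435 cells (Homo sapiens) for cytotoxicity, read by sulforhodamine B assay, with a stated time of 48 h, tested at 0.01 uM; on this read-out higher numbers stand for a weaker effect at the one concentration tested and lower numbers for a stronger effect. Compound 1 `COc1ccc(-c2cc(/C=C/C(=O)c3ccc(OC)c(OC)c3)[nH]n2)cc1` gives 97% in this assay, a number that shows only a weak effect at the single concentration used. Compound 2 `COc1cc(-c2cc(/C=C/C(=O)c3ccc(Cl)c(Cl)c3)[nH]n2)cc(OC)c1OC` gives 94% in this assay; it stands as the lower of the two numbers, but the gap to compound 1 lies within the scatter, so the two values cannot be told apart.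

The next compound, compound 3 `COc1ccc(C(=O)/C=C/c2cc(-c3cc(OC)c(OC)c(OC)c3)n[nH]2)cc1OC`, differs from compound 2 in one place: 3,4-dimethoxyphenyl in place of 3,4-dichlorophenyl on a carbonyl carbon. For the measured compounds named here, no step between two measured compounds is available to show what this exchange does in this assay, so the expectation rests on the two values alone, which both sit near the top of the percentage scale.

Because compound 2 gives 94%, compound 3 is expected to stay close to it, and the step of a number 1 percentage points higher from compound 2 to compound 3 (within the scatter) is estimated as none beyond the scatter. Compound 3 is thus expected to give about 95%, with a range from 84% to 102%.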

Compound 3, a percentage reported as activity, at one concentration (the size of the read-out at that concentration, not a potency): 95%
Beside the measured number, compound 3's estimate shows no gap at the digits printed; low and high end bracket the measured number.
By their numbers in this assay, from the lowest: compounds 2, 3 and 1 (each within the scatter of the next).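

For the compounds shown here, this step is the first single exchange that can be read at this position, on a carbonyl carbon. In this assay, putting 3,4-dimethoxyphenyl in place of 3,4-dichlorophenyl gives a number 1 percentage points higher from compound 2 to compound 3 (within the scatter) and so opens no gap that can be told from the scatter, even though the entering group has 10 heavy atoms against 8 and 2 hydrogen-bond acceptors against 0. No measurement shown here offers an explanation for this outcome.

The two values also sit near the top of the percentage scale at a single concentration, so this exchange may look silent here and still matter at a higher concentration, which a one-concentration read-out cannot reveal. Going by these compounds, it also remains open whether a quite different group on this carbonyl carbon, such as a phenyl ring carrying an amine or a carboxylic acid, or a longer carbon chain in place of the ring, would bring the number clearly down from where compound 2 and compound 3 stand.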